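The compounds below may be only part of what the source reports. "The series", "measured", "known", "first", "only" and "open" are said of these compounds alone.

In a physicochemical assay for lipophilicity, using the shake flask method, at pH 7.4 (on this read-out higher numbers stand for higher lipophilicity and lower numbers for lower lipophilicity), compound 1 `O=C(O)CCNC(=O)c1ccc(C(Oc2ccc(-n3cc(C(F)(F)F)cn3)cc2)C2CCC2)cc1` gives 2.6. Compound 2 `CCCC(Oc1ccc(-n2cc(C(F)(F)F)c(C)n2)cc1)c1ccc(C(=O)NCCC(=O)O)cc1` gives 2.8, within the scatter of compound 1, while compound 3 `CCCC(Nc1cc(C)c(-n2cc(C(F)(F)F)cn2)c(C)c1)c1ccc(C(=O)NCCC(=O)O)cc1` gives 2.2, lower than compound 1 by more than the scatter. Compound 4 `O=C(O)CCNC(=O)c1ccc(C(Oc2ccc(-n3cc(C(F)(F)F)cn3)cc2)C2CCCC2)cc1` has yet to be measured in this assay. It departs from compound 1 in one place, with cyclopentyl in place of cyclobutyl on a saturated chain carbon bound to an aromatic carbon and an oxygen on an aromatic ring. Going by the values given here, no measured pair shows this change, so the expectation rests on the structural change alone, and a modest upward step is expected. The estimated step is a number 0.40 log units higher from compound 1 to compound 4 (beyond the scatter). For compound 4 the expected value is 3, with an estimated range from 2.7 to 3.3.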

Compound 4, distribution coefficient: 3.3
Compound 4: middle estimate off by 0.30 log units, on the low side, within the range that was stated.
By their numbers in this assay, from the lowest: compound 3; then compounds 1 and 2 (each within the scatter of the next); then compound 4.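

In this assay, this position responds clearly to the size of the saturated ring: cyclopentyl in place of cyclobutyl gives a number 0.70 log units higher from compound 1 to compound 4 (beyond the scatter). Going by these compounds alone, none of the earlier compounds formed a pair differing in one place, so this is the first direct reading of any single change. Nothing measured here accounts for the size of this step. The compounds shown leave open whether cyclohexyl would continue the upward step, and whether tetrahydropyranyl, with an oxygen in the ring, would reverse it.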